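The source may report more compounds than this note shows. Statements on the series, on what has been measured and on what is new or still open speak of the compounds shown alone.

Measured compounds and their values: compound 1 `O=C(Nc1ccc(-n2ccc3c(NC(=O)c4ccccc4)ncnc32)cc1)Nc1ccc(Cl)c(C(F)(F)F)c1` with 4600 nM; compound 2 `Nc1ncnc2c1ccn2-c1ccc(NC(=O)Nc2ccc(Cl)c(C(F)(F)F)c2)cc1` with 8100 nM; compound 3 `O=C(Nc1ccc(-n2ccc3c(NC(=O)c4ccccc4)ncnc32)cc1)c1cc(C(F)(F)F)cc(C(F)(F)F)c1` with 2000 nM.

All three were read in a functional assay on A375P cells (Homo sapiens) for antiproliferative activity, read by MTT assay, with a stated time of 24 h; a higher number here means a weaker inhibitor, a lower number a stronger inhibitor. Compound 3 gives the lowest number of the three; compound 1 is nearest, and compound 2 furthest, both gaps lying beyond the scatter. Compound 1 and compound 2 differ only by hydrogen in place of benzoyl on a nitrogen on an aromatic ring, and that step, a 1.8-fold higher number from compound 1 to compound 2 (0.25 log units; within the scatter), stays within the scatter. Among the measured compounds shown here, compound 1 and compound 3 differ in the group carried on the amide of the shared core; no step is given for that pair, and their two values only show that compound 3 lies lower.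

Compound 4 `Cc1cn(-c2cc(C(=O)Nc3ccc(-n4ccc5c(NC(=O)c6ccccc6)ncnc54)cc3)cc(C(F)(F)F)c2)cn1` is not yet measured. It differs from compound 3 by 4-methyl-1H-imidazol-1-yl in place of trifluoromethyl on an aromatic carbon. No measured step touches this position, and the single listed step, the change from compound 1 to compound 2, concerns a different place and gives no guide to direction. The step is therefore taken as open, with a change of modest size in either direction, and compound 4 is expected at 1500 nM, between 400 nM and 6000 nM, which means an expected step of a 1.3-fold lower number from compound 3 to compound 4 (0.12 log units; within the scatter) from compound 3.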

Compound 4, half-maximal inhibitory concentration: 800 nM
Estimate against measurement, compound 4: 1.9-fold (0.27 log units) above, and the stated range covers the measured number.
By their numbers in this assay, from the lowest: compound 4; then compound 3; then compounds 1 and 2 (each within the scatter of the next).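

In this assay, this place on the aromatic ring proves open to change, with 4-methyl-1H-imidazol-1-yl in place of trifluoromethyl giving a 2.5-fold lower number from compound 3 to compound 4 (0.40 log units; beyond the scatter), a step that lies beyond the scatter. The earlier compounds offered no step at this place, and their one listed step concerned a different part of the molecule, so this is the first direct reading here: a ring-bearing group can stand on this aromatic carbon, meta to a trifluoromethyl group, and the antiproliferative number still falls rather than rises. No measurement shown bears on why the number moves in this direction.

With a single replacement at this place, the compounds shown leave open whether the lower number goes with the imidazole ring itself, its methyl group or simply the exchange of trifluoromethyl, and a plain 1H-imidazol-1-yl group, a morpholine ring or a dimethylamino group would help separate these readings. They also leave open whether the trifluoromethyl group that remains on the same ring of compound 4 matters, which a hydrogen or a chlorine atom in its stead could test.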